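Shortening the Amide Substituent: From Compound 2 to Compound 3

A few compounds are considered here, and "the series" means these few. Any claim that something is new, unique, unknown or untested is made for them only; others in the source may bear on it.

Measured so far:
compound 1, `CCOC(=O)[C@@H]1CCCN(S(=N)(=O)c2ccc(S(=O)(=O)N(CC)CC)cc2)C1`: 13300 nM
compound 2, `CCN(CC)S(=O)(=O)c1ccc(S(=O)(=O)N2CCC[C@@H](C(=O)NC3CN(C(=O)C4CC4)C3)C2)cc1`: 18500 nM

Both numbers come from a functional assay on BXPC-3 cells (Homo sapiens) for inhibition, read by MTT assay, with a stated time of 7 days; on this read-out lower numbers stand for stronger inhibition and higher numbers for weaker inhibition. Of the two, the number of compound 2 is the higher, yet compound 1 lies within the scatter of it, so the two cannot be told apart. Compound 3, `CCN(CC)S(=O)(=O)c1ccc(S(=O)(=O)N2CCC[C@@H](C(=O)NC3COC3)C2)cc1`, differs from compound 2 in one place: oxetan-3-yl in place of 1-(cyclopropylcarbonyl)azetidin-3-yl on an amide-type nitrogen. Among the compounds with values here, no measured pair shows this change, so nothing in the data sets its size; with both measured compounds weak, a step of no more than the scatter is expected in either direction. Compound 3 is therefore expected to give about 20000 nM, within 8000 nM to 50000 nM. The expected step is a 1.1-fold higher number from compound 2 to compound 3 (0.03 log units; within the scatter).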

Compound 3, half-maximal inhibitory concentration: 13800 nM
Beside the measured number, compound 3's estimate is 1.4-fold (0.16 log units) above it; measured number inside the range.
By their numbers in this assay, from the lowest: compounds 1, 3 and 2 (each within the scatter of the next).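

In this assay the amide-type nitrogen carries either 1-(cyclopropylcarbonyl)azetidin-3-yl or the much smaller oxetan-3-yl, and the exchange gives a 1.3-fold lower number from compound 2 to compound 3 (0.13 log units; within the scatter), so compound 2 and compound 3 cannot be told apart. At this position, then, going from 9 heavy atoms to 4 does not separate the two numbers. The data give no measured basis for explaining this result.

Still open, as far as these compounds go, is whether an amine or a carboxylic acid on this amide nitrogen would move the number beyond the scatter. A longer alkyl chain there poses the same question.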